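The compounds below may be only part of what the source reports. "The series", "measured", "known", "first", "only" and "open" are said of these compounds alone.

Measured compounds:

compound 1, `CN(C)C(=O)c1cc2cnc(Nc3ccc(S(=O)(=O)NCCCCCN=C=S)cc3)nc2n1C1CCCC1` — 83.4% in a functional assay on NCI-H1299 cells (Homo sapiens) for inhibition, read by CCK-8 assay, with a stated time of 72 h, tested at 10 uM; a lower number here means a weaker effect, a higher number a stronger effect of the compound at the concentration tested
compound 2, `CN(C)C(=O)c1cc2cnc(Nc3ccc(S(=O)(=O)NCCCCCCCN=C=S)cc3)nc2n1C1CCCC1` — 83% in this assay

Compound 1 stands highest of the two numbers, but its nearest neighbour, compound 2, lies within the scatter of it, so the two cannot be ordered. Within the data shown here, the single measured step, a number 0.4 percentage points lower from compound 1 to compound 2 (within the scatter), puts a group of 5 heavy atoms in place of a group of 3 heavy atoms on a saturated chain carbon, five bonds along the chain from a sulfonamide nitrogen, and it leaves the inhibition essentially unchanged.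

Compound 3, `CN(C)C(=O)c1cc2cnc(Nc3ccc(NC(=O)CCCCCN=C=S)cc3)nc2n1C1CCCC1`, is not yet measured. Relative to compound 1 it carries a group of 11 heavy atoms (7 carbon, 2 nitrogen, 1 oxygen, 1 sulfur; no ring) in place of a group of 12 heavy atoms (6 carbon, 2 nitrogen, 2 oxygen, 2 sulfur; no ring), on an aromatic carbon. This change is of a different kind from the measured one: the step from compound 1 to compound 2 alters only the length of the chain, whereas here the group attached to the aromatic carbon itself is exchanged. Among the measured compounds shown here, no measured pair bears directly on such an exchange, so the expectation rests on the observation that the compounds so far sit close together. Compound 3 is therefore estimated at 78%, in a range from 55% to 92%. The step expected is a number 5.4 percentage points lower from compound 1 to compound 3 (within the scatter), which lies within the scatter.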

Compound 3, a percentage reported as inhibition, at one concentration (the size of the read-out at that concentration, not a potency): 85%
For compound 3 the middle estimate is 7 percentage points below the measured one, and the stated range covers the measured number.
By their numbers in this assay, from the lowest: compounds 2, 1 and 3 (each within the scatter of the next).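

In this assay, the exchange on the aromatic carbon, para to a large group, gives a number 1.6 percentage points higher from compound 1 to compound 3 (within the scatter) and so leaves the read-out at the level seen so far. Until now, only the length of the chain beyond the sulfonamide nitrogen had been varied; this result shows that the inhibition at this one concentration also holds when the sulfonamide-linked group of 12 heavy atoms gives way to the amide-linked group of 11 heavy atoms, so the sulfonamide is not required for it among these compounds. Nothing available explains why the read-out holds across this exchange.

All three compounds carry the isothiocyanate at the end of a saturated chain, so they leave open whether the inhibition would persist with a simple amine or an acetamide at that chain end. They also leave open how a much shorter chain would fare on the amide, and, since each number is the size of the effect at one concentration, whether these compounds differ in potency.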